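The source may report more compounds than this note shows. Statements on the series, on what has been measured and on what is new or still open speak of the compounds shown alone.

Compound 1 `Cc1cccc(-c2ccc(N(C[C@@H](N)CC(C)C)C(=O)[C@@H]3C[C@H]3c3ccccc3)cc2)c1` gives 1200 nM in a functional assay for agonist activity at G protein-coupled receptor 88 (Homo sapiens), read by HTRF and cAMP accumulation; on this read-out higher numbers stand for an effect only at larger amounts of compound and lower numbers for an effect already at smaller amounts.
Compound 2 `CCCc1ccc(-c2ccc(N(C[C@@H](N)[C@@H](C)CC)C(=O)[C@@H]3C[C@H]3c3ccccc3)cc2)cc1` gives 61 nM in this assay.

Of the two measured compounds, compound 2 stands with the lower number and compound 1 with the higher one, a gap that lies beyond the scatter. Among the measured compounds shown here, the two structures differ in several places at once, so no single step links them, and the gap only shows what the two values are. Compound 3 `CCOc1ccc(-c2ccc(N(C[C@@H](N)[C@@H](C)CC)C(=O)[C@@H]3C[C@H]3c3ccccc3)cc2)cc1` has not yet been measured. It differs from compound 2 in one place: ethoxy in place of propyl on an aromatic carbon, para to a large group. For the measured compounds named here, no measured pair shows a change of this kind, so nothing in the data fixes its size. A small step is expected from compound 2 to compound 3, a 1.6-fold higher number from compound 2 to compound 3 (0.21 log units; within the scatter), close to the scatter and with a slight lean toward a higher number. Compound 3 is therefore estimated at 100 nM in this assay, with a range from 30 nM to 400 nM.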

Compound 3, half-maximal effective concentration: 90 nM
Beside the measured number, compound 3's estimate is 1.1-fold (0.05 log units) above it; the range from low to high includes it.
By their numbers in this assay, from the lowest: compounds 2 and 3 (each within the scatter of the next); then compound 1.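

Going from 4-propylphenyl to 4-ethoxyphenyl gives a 1.5-fold higher number from compound 2 to compound 3 (0.17 log units; within the scatter) in this assay and is the first single change seen at this aromatic carbon, para to a large group. The swap brings in an oxygen and a hydrogen-bond acceptor while the count of heavy atoms stays the same, yet the two values stand within the scatter of each other, so on this read-out ethoxy and propyl cannot be told apart here. No measurement at hand explains why these two groups read alike.

Still open, on these data alone, is whether a longer chain such as butyl, an amine or a carboxylic acid on this same carbon would also read alike. Also open, as far as these compounds go, is whether the swap from propyl to ethoxy would give a similar result on the core of compound 1.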